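The compounds below may be only part of what the source reports. "The series", "measured", "known", "first", "only" and "open" are said of these compounds alone.

- Compound 1 `Clc1cc(Cl)cc(CNC2CCCC(c3nc4nc(Cl)ccc4[nH]3)C2)c1` gives 32300 nM as measured
- Compound 2 `Clc1cc(Cl)cc(CNC2CCCN(c3nc4nc(Cl)ccc4[nH]3)C2)c1` gives > 50000 nM as a limit

In a toxicity assay on HepG2 cells (Homo sapiens) for cytotoxicity, read by resazurin assay, with a stated time of 48 h (on this read-out higher numbers stand for an effect only at larger amounts of compound and lower numbers for an effect already at smaller amounts), compound 2 stands at > 50000 nM and this is a limit of the assay, not a number. The next compound, compound 3 `Clc1cc(Cl)cc(CN[C@H]2CCCN(c3nc4nc(Cl)ccc4[nH]3)C2)c1`, has the same atoms and bonds as compound 2 and differs only in how one stereocentre is drawn (the two compounds have the same atoms and bonds; at least one stereo element is drawn with a configuration in one of them and without one in the other: 1 of 1 stereo elements differ; a stereocentre at a saturated ring carbon is drawn without a configuration in compound 2 and S in compound 3). Going by the values given here, no measured pair shows what such a change does here. The expected step that the limit leaves unreadable from compound 2 to compound 3 in this assay is therefore none beyond the usual scatter, in neither direction. Compound 1, at 32300 nM, also shows an effect only at large amounts. Compound 3 may well return a limit too. For compound 3 the expected value is 55000 nM with an estimated range from 25000 nM to 100000 nM as the likely span.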

Compound 3, half-maximal effective concentration: 49000 nM
Beside the measured number, compound 3's estimate is 1.1-fold (0.05 log units) above it; measured number inside the range.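

In this assay compound 2 stands at > 50000 nM, which is a limit of the assay and not a number. Drawing the saturated ring carbon as S gives an at least 1.0-fold lower number from compound 2 to compound 3 (0.00 log units; that floor lies within the scatter), so this change at this position shows no effect that can be told apart from the scatter of repeated measurements. The comparison is also not one between two defined forms: the fact that one of compounds 2 and 3 is drawn with a defined configuration and the other without, at the place where they differ

The compounds shown leave open what the R configuration at this ring carbon would give in this assay. They also leave open whether a carboxylic acid or a longer chain on the shared core would bring the effect down to smaller amounts of compound.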